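A few compounds are considered here, and "the series" means these few. Any claim that something is new, unique, unknown or untested is made for them only; others in the source may bear on it.

In a physicochemical assay for lipophilicity, using the shake flask method, in phosphate buffer, measured as octanol-water partition, with a stated time of 24 h, at pH 7.4, tested at 100 uM (a higher number here means a more lipophilic compound, a lower number a more polar compound), compound 1 (`COc1cc(C)c(-c2cccc(COc3ccc(S(=O)(=O)CC(=O)O)cc3)c2)c(C)c1`) gives 2.45 and compound 2 (`O=C(O)CS(=O)(=O)c1ccc(OCc2cccc(-c3ccccc3)c2)cc1`) gives 2.13 on the same scale. Among the compounds with values here, compound 3 (`O=C(O)CS(=O)(=O)c1ccc(OCc2cccc(-c3ccccc3F)c2)cc1`) has no number ("not determined" (no result reported)), so no measured step starts from it. Compound 4 (`O=C(O)CS(=O)(=O)c1ccc(OCc2cccc(-c3ccccc3C(F)(F)F)c2)cc1`) differs from compound 3 by trifluoromethyl in place of fluoro on an aromatic carbon in one place: trifluoromethyl in place of fluoro on an aromatic carbon, ortho to a large group. Within the data shown here, the only measured step bearing on this is a number 0.32 log units lower from compound 1 to compound 2 (beyond the scatter) and it is modest, with phenyl in place of 4-methoxy-2,6-dimethylphenyl. That single step suggests a rise of similar modest size in this assay from fluoro to trifluoromethyl, though this remains an expectation. For compound 4 the estimated value is 2.55 with an expected range from 2.15 to 2.95 in this series.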

Compound 4, distribution coefficient: 2.95
Estimate against measurement, compound 4: 0.40 log units below; measured number inside the range.
By their numbers in this assay, from the lowest: compound 2; then compound 1; then compound 4.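

In this assay, replacing a hydrogen with trifluoromethyl, ortho to a large group, gives a number 0.82 log units higher from compound 2 to compound 4 (beyond the scatter). Within the data shown here, this is the first reading of a single substituent at this position, as the earlier step exchanged a whole aromatic group. With 2-(trifluoromethyl)phenyl in place of 4-methoxy-2,6-dimethylphenyl, the series shows a number 0.50 log units higher from compound 1 to compound 4 (beyond the scatter).

Compound 3 has no number, so the fluoro to trifluoromethyl step cannot be read, and nothing available bears on the cause of these steps. Going by these compounds, how a nitrile or an amine on this aromatic carbon would read in this assay remains open.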